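Removal of the heptyl chain in a purine series

The compounds below may be only part of what the source reports. "The series", "measured", "known", "first", "only" and "open" are said of these compounds alone.

Three compounds of the series have a number in a functional assay on SW480 cells (Homo sapiens) for antiproliferative activity, read by MTT assay, with a stated time of 48 h; on this read-out lower numbers stand for stronger inhibition and higher numbers for weaker inhibition. Compound 3 `CCCCCCCCC(CCO)n1cnc2c(Cl)ncnc21` gives 1370 nM. Compound 2 `CCCCCCCC(CCO)n1cnc2c(Cl)nc(F)nc21` gives 26100 nM, the highest of the two numbers measured. Compound 1 `CC(CCO)n1cnc2c(Cl)ncnc21` gives only a limit of this assay, > 50000 nM; one of the three values sits at that limit (the limit of > 50000 nM in this assay, at which 1 of the 3 values shown sits). Compound 4 `OCCCn1cnc2c(Cl)nc(F)nc21` is not yet measured in this assay.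

The change from compound 3 to compound 1 is hydrogen in place of heptyl on a saturated chain carbon, two bonds along the chain from an aromatic nitrogen. Its measured step is an at least 36-fold higher number from compound 3 to compound 1 (1.56 log units; beyond the scatter). The change from compound 2 to compound 4 is hydrogen in place of heptyl on a saturated chain carbon bound to an aromatic nitrogen and a saturated chain carbon. The group that leaves and the hydrogen that enters are the same in both, but the place is not the same word for word: in compound 3 the carbon is two bonds along the chain from an aromatic nitrogen, in compound 2 it is bound to an aromatic nitrogen and a saturated chain carbon, so it is the same kind of change, not the same. The difference between the core of compound 2 and the core of compound 3 is not broken down here. Compound 2 sits far from compound 3 in this assay already, and a limit is likely once the heptyl is gone. The step from compound 2 to compound 4 in this assay is expected to be a 7.7-fold higher number from compound 2 to compound 4 (0.88 log units; beyond the scatter), resting on the step from compound 3 to compound 1. Compound 4 is estimated at 200000 nM, between 50000 nM and 800000 nM.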

Compound 4, half-maximal inhibitory concentration: 29700 nM
The estimate for compound 4 lay 6.7-fold (0.83 log units) above the measured number; measured number below the stated range.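

In this assay the replacement of heptyl by hydrogen reads as a 1.1-fold higher number from compound 2 to compound 4 (0.06 log units; within the scatter), so on this core the change leaves the number within the scatter. The same kind of change does not carry over in size from one core to the other: the same change on two cores in this assay, an at least 36-fold higher number (1.56 log units; beyond the scatter) from compound 3 to compound 1 and a 1.1-fold higher number (0.06 log units; within the scatter) from compound 2 to compound 4, at least 32-fold (1.50 log units) apart, beyond the scatter of two such steps What this does not show is which difference separates the two steps: the cores differ, the printed place of the change differs, only two pairs are available, and the earlier step rests on the limit of compound 1, which is a limit and not a number: the limit of > 50000 nM in this assay, at which 1 of the 4 values shown sits.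

The compounds shown leave open whether a larger step would return on the core of compound 2 with a longer chain in place of heptyl, or whether that core stays flat in this read-out whatever the chain. They also leave open how an amine or a carboxylic acid in place of the hydroxyl would behave on either core, and whether a step measured between two true numbers, with no limit at either end, would still keep the two cores apart.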